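A Small Structural Step from Compound 3

The compounds below may be only part of what the source reports. "The series", "measured", "known", "first", "only" and "open" are said of these compounds alone.

In an ADME assay on microsomes from liver (Mus musculus) for metabolic stability, read by mass spectrometry, with a stated time of 40 min, tested at 1 uM (on this read-out higher numbers stand for a more stable compound and lower numbers for a less stable compound), compound 3 `COc1cc(N2CCC(C(=O)N3CCOCC3)CC2)ccc1Nc1nc(NC2CCCCC2)c2nc[nH]c2n1` gives 70%. That value lies within the usual scatter of both other measured compounds: compound 1 `COc1cc(N2CCN(C(=O)C3CCC(O)CC3)CC2)ccc1Nc1nc(NC2CCCCC2)c2nc[nH]c2n1` at 68% and compound 2 `COc1cc(N2CCC(C(=O)N3CCC(N(C)C)C3)CC2)ccc1Nc1nc(NC2CCCCC2)c2nc[nH]c2n1` at 60%. So compound 3 cannot be told apart from either on these numbers.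

Compound 4 `COc1cc(N2CCC(CC(=O)N3CCOCC3)CC2)ccc1Nc1nc(NC2CCCCC2)c2nc[nH]c2n1` carries ((morpholin-4-yl)carbonyl)methyl in place of (morpholin-4-yl)carbonyl on a saturated ring carbon. Among the measured compounds shown here, no measured pair shows this kind of change on its own. The nearest evidence is a swap at the carbonyl carbon of the same side chain, morpholin-4-yl in place of 3-(dimethylamino)pyrrolidin-1-yl, which gives a number 10 percentage points higher from compound 2 to compound 3 (within the scatter). Even that larger swap stays within the scatter, so only a small shift seems likely here. The expected change is a number 5 percentage points lower from compound 3 to compound 4 (within the scatter), which means no step beyond the scatter is expected in this assay. For compound 4 the estimate is 65%, with an expected range from 50% to 80%.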

Compound 4, percent of the compound remaining: 61%
Compound 4: middle estimate off by 4 percentage points, on the high side; measured number inside the range.
By their numbers in this assay, from the lowest: compounds 2, 4, 1 and 3 (each within the scatter of the next).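

In this assay the change from (morpholin-4-yl)carbonyl to ((morpholin-4-yl)carbonyl)methyl on this saturated ring carbon gives a number 9 percentage points lower from compound 3 to compound 4 (within the scatter) and so does not separate the two compounds. Among the compounds shown here, this is the first measured pair to test this change on its own, and it shows that the side chain can carry this extra carbon with no step beyond the scatter. Set against the (3-(dimethylamino)pyrrolidin-1-yl)carbonyl side chain, the new group gives a number 1 percentage points higher from compound 2 to compound 4 (within the scatter) and again no clear separation. No available evidence accounts for these numbers.

The compounds shown leave open whether a longer chain, or a carboxylic acid or an amine in place of the morpholine amide, would step beyond the scatter. They also leave open whether the same added carbon would give a similar step with the 3-(dimethylamino)pyrrolidin-1-yl amide.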